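Swapping cyclohexyl for 2-fluorophenyl beside the ring nitrogen

This account rests on a few compounds, and the source may have more. Where it says the series, first, only, none or still open, it means among the compounds named here.

Compound 2 `CNC(=O)c1cc(C(=O)NC2CC2)cn(CC2CCCCC2)c1=O` was examined in a physicochemical assay for solubility; a higher number here means a more soluble compound, a lower number a less soluble compound. Compound 2 reaches the limit of that assay, >= 148 ug/mL, so only a bound and no exact number is known for it. Two other compounds sharing the same core give context. Compound 1 `CNC(=O)c1ccc(=O)n(Cc2cc(Br)ccc2F)c1` likewise sits at a limit, >= 143 ug/mL, in this assay. Compound 3 `CNC(=O)c1cc(C(=O)NCC(C)C)cn(Cc2ccccc2)c1=O` gives 43 ug/mL in this assay. That is an exact number, and it lies lower than what the other two compounds reach. Within the data shown here, no pair of measured compounds differs in a single place, so the size of any one change among them cannot be read off.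

Compound 4 `CNC(=O)c1cc(C(=O)NC2CC2)cn(Cc2ccccc2F)c1=O` has not yet been measured. It differs from compound 2 in one place: 2-fluorophenyl in place of cyclohexyl on a saturated chain carbon bound to an aromatic nitrogen. Compound 2 and compound 1 both sat at their limits. Compound 3, which carries a different chain on the ring nitrogen and a different amide, came in at 43 ug/mL. The writer expects compound 4 to remain soluble, with a step from compound 2 of an at least 1.3-fold lower number from compound 2 to compound 4 (0.12 log units; that floor lies within the scatter), at most a modest drop and possibly none beyond the scatter. The estimate for compound 4 in this assay is 110 ug/mL, between 40 ug/mL and 200 ug/mL, with a fair chance that the assay again returns only a limit.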

Compound 4, solubility: >= 145 ug/mL
Compound 4: only a limit was reported; the forecaster's own chance of this, stated with the estimate: 40%; at least 1.3-fold (0.11 log units) between middle value and limit.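

In this assay compound 4 returned only a limit, >= 145 ug/mL. Compound 2 also stands at a limit, so no step can be read between compound 2 and compound 4. The compounds shown leave open how soluble either compound really is, and whether 2-fluorophenyl in place of cyclohexyl changes the read-out at all.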